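The source may report more compounds than this note shows. Statements on the series, on what has been measured and on what is new or still open speak of the compounds shown alone.

Compound 1 `COC1=C(OC)C(=O)C(CCCCCCCCCCOc2c(O)cc(O)cc2O)=C(C)C1=O` reaches only a limit, > 200000 nM, in a functional assay on HL-60 cells (Homo sapiens) for antiproliferative activity, read by MTT assay, with a stated time of 48 h; a higher number here means a weaker inhibitor, a lower number a stronger inhibitor.
Compound 2 `COC1=C(OC)C(=O)C(CCCCCCCCCCn2ccnc2)=C(C)C1=O` gives 15000 nM in this assay.

Within the data shown here, compound 2 holds the only measured number here; the other result is a limit, (the limit of > 200000 nM in this assay, at which 1 of the 2 values shown sits). Among the measured compounds shown here, the one measured step, an at least 13-fold lower number from compound 1 to compound 2 (1.12 log units; beyond the scatter), shows that moving from the trihydroxyphenoxy end group to the imidazolyl end group made the number fall sharply. Compound 3 `COC1=C(OC)C(=O)C(CCCCCCCCCCOc2cc(O)cc(O)c2)=C(C)C1=O` goes the other way: 3,5-dihydroxyphenoxy in place of 1H-imidazol-1-yl on a saturated chain carbon, ten or more bonds along the chain from a double-bonded ring carbon. This change partly reverses the measured step, bringing back a hydroxylated phenoxy end group, so a large rise in the number is expected from compound 2 to compound 3, quite possibly back to a limit. The step is estimated as a 6.7-fold higher number from compound 2 to compound 3 (0.82 log units; beyond the scatter). For compound 3 the expected value in this assay is 100000 nM, with a range from 30000 nM to 300000 nM.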

Compound 3, half-maximal inhibitory concentration: 63000 nM
The estimate for compound 3 lay 1.6-fold (0.20 log units) above the measured number; the measured number falls inside the stated range.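

Putting 3,5-dihydroxyphenyl in place of 2,4,6-trihydroxyphenyl on the chain oxygen gives an at least 3.1-fold lower number from compound 1 to compound 3 (0.50 log units; beyond the scatter) in this assay, so at this chain end the number depends on the hydroxyl pattern of the phenoxy group, not merely on its presence. That step is only a bound, since compound 1 stands at a limit and not at a number: the limit of > 200000 nM in this assay, at which 1 of the 3 values shown sits. Even so, 3,5-dihydroxyphenoxy in place of 1H-imidazol-1-yl still gives a 4.2-fold higher number from compound 2 to compound 3 (0.62 log units; beyond the scatter), so of these three compounds the one ending in 1H-imidazol-1-yl remains the strongest inhibitor.

The compounds shown leave open whether an amine or a carboxylic acid at the chain end would match 1H-imidazol-1-yl. They also leave open how a phenoxy group with a single hydroxyl, or a shorter chain, would fare.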